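Swapping methoxy for nitro on an inactive compound

The source may report more compounds than this note shows. Statements on the series, on what has been measured and on what is new or still open speak of the compounds shown alone.

In a functional assay on K562 cells (Homo sapiens) for inhibition, read by sulforhodamine B assay, with a stated time of 48 h (a lower number here means a stronger inhibitor of growth, a higher number a weaker inhibitor of growth), compound 2 `COc1ccc(-c2c(CNC(C)(C)C)c(C(=O)O)nn2-c2ccccc2)cc1` gives only a limit, > 659000 nM, and not a number. In this assay, compound 1 `CCOC(=O)c1nn(-c2ccccc2)c(-c2ccc([N+](=O)[O-])cc2)c1CNC(C)(C)C` has two entries that lie far apart, 12000 nM; 191000 nM (2 entries). Compound 3 `CC(C)(C)NCc1c(C(=O)O)nn(-c2ccccc2)c1-c1ccc([N+](=O)[O-])cc1` carries a 4-nitrophenyl group where compound 2 has a 4-methoxyphenyl group, para to a large group: nitro in place of methoxy on an aromatic carbon. With only that limit as a starting point, a small move toward stronger inhibition is expected, possibly none beyond the scatter, and the estimated step is an at least 1.3-fold lower number from compound 2 to compound 3 (0.11 log units; that floor lies within the scatter). For compound 3 the estimated value is 500000 nM, with an expected range of 150000 nM to 900000 nM.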

Compound 3, concentration for 50% growth inhibition: > 634000 nM
Compound 3: only a limit was reported; the forecaster's own chance of this, stated with the estimate: 60%; middle value at least 1.2-fold (0.10 log units) away from the limit.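

In this assay compound 3 gives only a limit, > 634000 nM. Among the compounds shown here, compound 2 also gives only a limit, so no step between compound 2 and compound 3 can be read. As far as these compounds go, how nitro and methoxy truly compare on this core stays open.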